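Replacing Methoxymethyl with 1,1-Difluoroethyl on the Shared Core

A few compounds are considered here, and "the series" means these few. Any claim that something is new, unique, unknown or untested is made for them only; others in the source may bear on it.

In a physicochemical assay for solubility, at pH 6.5 (on this read-out lower numbers stand for lower solubility and higher numbers for higher solubility), compound 3 (`COCc1nc2nc(C)cc(Nc3ccc(S(F)(F)(F)(F)F)cc3)n2n1`) gives 63000 nM and stands highest of the three measured compounds. Compound 1 (`COCCc1nc2nc(C)cc(Nc3ccc(S(F)(F)(F)(F)F)cc3)n2n1`) gives 31000 nM and compound 2 (`Cc1cc(Nc2ccc(S(F)(F)(F)(F)F)cc2)n2nc(C3CC3)nc2n1`) gives 16000 nM on the same scale. Compound 4 (`Cc1cc(Nc2ccc(S(F)(F)(F)(F)F)cc2)n2nc(C(C)(F)F)nc2n1`) differs from compound 3 as follows: 1,1-difluoroethyl in place of methoxymethyl on an aromatic carbon with 1,1-difluoroethyl in place of methoxymethyl on an aromatic carbon. Going by the values given here, no measured compound carries 1,1-difluoroethyl. The nearest guide is the exchange of cyclopropyl and methoxymethyl at this place (a 3.9-fold higher number from compound 2 to compound 3 (0.60 log units; beyond the scatter)), a modest step. The chain change (a 2.0-fold higher number from compound 1 to compound 3 (0.31 log units; beyond the scatter)) is smaller, and the remaining step (a 1.9-fold lower number from compound 1 to compound 2 (0.29 log units; within the scatter)) lies within the scatter. A modest fall is therefore expected in this assay (a 3.2-fold lower number from compound 3 to compound 4 (0.50 log units; beyond the scatter)). Compound 4 is estimated at 20000 nM (7000 nM to 50000 nM).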

Compound 4, solubility: 30000 nM
For compound 4 the middle estimate is 1.5-fold (0.18 log units) below the measured one; the range from low to high includes it.
By their numbers in this assay, from the lowest: compounds 2, 4 and 1 (each within the scatter of the next); then compound 3.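

In this assay, 1,1-difluoroethyl at this place on the shared core stands clearly apart from methoxymethyl (a 2.1-fold lower number from compound 3 to compound 4 (0.32 log units; beyond the scatter)). It does not separate from the other two groups at this place (a 1.9-fold higher number from compound 2 to compound 4 (0.27 log units; within the scatter); a 1.0-fold lower number from compound 1 to compound 4 (0.01 log units; within the scatter)), so among the four groups shown only methoxymethyl stands apart. No measurement shown here accounts for this difference.

Going by these compounds, whether an amine, a carboxylic acid or a longer chain at this place would stand with methoxymethyl or with the other three groups remains open. So does whether the same order would hold on another core.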